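The compounds below may be only part of what the source reports. "The series", "measured", "known", "first", "only" and "open" are said of these compounds alone.

In a functional assay on A549 cells (Homo sapiens) for cytotoxicity (on this read-out lower numbers stand for stronger inhibition and higher numbers for weaker inhibition), compound 1 `CCCCCCCCCCCCCC[C@@H]1N[C@@H](CO)[C@@H]1O` gives 0.34 ug/mL and compound 2 `CCCCCCCCCCCCCC[C@H]1N[C@@H](CO)[C@@H]1O` gives 0.22 ug/mL. Compound 2 therefore stands level with compound 1, since the two numbers lie within the scatter of each other. Compound 3 `CCCCCCCCCCCCCC[C@@H]1N[C@H](CO)[C@@H]1O` has not yet been measured. It has the same atoms and bonds as compound 2 and differs only in configuration as drawn: the two compounds have the same atoms and bonds and differ only in configuration as drawn: 2 of 3 stereo elements differ; a stereocentre at a saturated ring carbon is drawn R in compound 2 and S in compound 3; a stereocentre at a saturated ring carbon is drawn S in compound 2 and R in compound 3. Among the measured compounds shown here, the one measured step that bears on this change is a 1.5-fold lower number from compound 1 to compound 2 (0.19 log units; within the scatter), which stays within the scatter and also alters only configuration. That step touched fewer stereo elements than the present change, so it offers only limited guidance, and the range is kept wide. In this assay, the expected change is a 1.4-fold higher number from compound 2 to compound 3 (0.13 log units; within the scatter), which means no step beyond the scatter is anticipated. Compound 3 is estimated at 0.3 ug/mL, with an expected range from 0.12 ug/mL to 0.9 ug/mL.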

Compound 3, half-maximal inhibitory concentration: > 2 ug/mL
Compound 3: no number, only a limit (the forecaster's own chance of this, stated with the estimate: 3%); at least 6.6-fold (0.82 log units) between middle value and limit.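

In this assay compound 3 gives > 2 ug/mL, which is a limit of the assay and not a number. Inversion at a single stereocentre at a saturated ring carbon is now enough to carry the read-out beyond the scatter, with an at least 5.8-fold higher number from compound 1 to compound 3 (0.76 log units; beyond the scatter) and, where two stereo elements differ, an at least 9.0-fold higher number from compound 2 to compound 3 (0.95 log units; beyond the scatter), and this shift arises because of configuration alone: the fact that compounds 1 and 3 differ only in the configuration as drawn The earlier step, a 1.5-fold lower number from compound 1 to compound 2 (0.19 log units; within the scatter), also altered one such stereocentre, so among these compounds the read-out does not respond equally to every change of configuration.

Going by these compounds, because compound 3 is known only through a limit, the true size of both steps remains open. The compounds also leave open whether a carboxylic acid or a longer chain would be tolerated on the shared core in any of these configurations.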